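The compounds below may be only part of what the source reports. "The series", "measured", "known", "first", "only" and "open" are said of these compounds alone.

Measured so far:
Compound 1 `N#CC1=C(N)Oc2c(c3nc4ccccc4nc3c3ccccc23)C12C(=O)N(Cc1cnnn1-c1ccccc1Br)c1ccccc12`; in a functional assay on HCT-116 cells (Homo sapiens) for antiproliferative activity, read by MTT assay, with a stated time of 48 h (a lower number here means a stronger inhibitor, a higher number a weaker inhibitor), compound 1 gives > 50000 nM, which is a limit of the assay and not a number.
Compound 2 `N#CC1=C(N)Oc2c(c3nc4ccccc4nc3c3ccccc23)C12C(=O)N(Cc1cnnn1-c1cccc(S(N)(=O)=O)c1)c1ccccc12`; in this assay compound 2 gives 11300 nM.
Compound 3 `N#CC1=C(N)Oc2c(N)cc3nc4ccccc4nc3c2C12C(=O)N(Cc1cnnn1-c1ccc(Cl)cc1)c1ccccc12`; in this assay compound 3 gives > 50000 nM, again a limit of the assay rather than a number.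

Compound 3 thus stands at the limit, where two of the three values sit (the limit of > 50000 nM in this assay, at which 2 of the 3 values shown sit); only compound 2 returns a number in this assay, so compound 3 cannot be placed against it beyond saying that compound 2 is the weaker of the limit values' neighbours by at least the gap shown.

Compound 4 `Cc1ccc(Cl)cc1-n1nncc1CN1C(=O)C2(C(C#N)=C(N)Oc3c(N)cc4nc5ccccc5nc4c32)c2ccccc21` differs from compound 3 by 5-chloro-2-methylphenyl in place of 4-chlorophenyl on an aromatic nitrogen. Going by the values given here, the only measured step on this aromatic nitrogen, an at least 4.4-fold lower number from compound 1 to compound 2 (0.64 log units; beyond the scatter), exchanges 2-bromophenyl for 3-sulfamoylphenyl and starts from a limit; it does not speak to swapping one chlorophenyl for a chlorophenyl carrying an added methyl. Among the compounds with values here, no measured step bears directly on the present change, so the expectation for a step that the limit leaves unreadable from compound 3 to compound 4 is a step within the scatter, most likely another limit value. Compound 4 is accordingly estimated at 60000 nM, in the range 20000 nM to 200000 nM.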

Compound 4, half-maximal inhibitory concentration: 37200 nM
For compound 4 the middle estimate is 1.6-fold (0.21 log units) above the measured one; measured number inside the range.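

In this assay compound 3 gives > 50000 nM, which is a limit of the assay and not a number. On this aromatic nitrogen, the exchange of 4-chlorophenyl for 5-chloro-2-methylphenyl gives an at least 1.3-fold lower number from compound 3 to compound 4 (0.12 log units; that floor lies within the scatter), so this core now has a measured value among the compounds shown, but no gain beyond the scatter is established. The step can be read only as a floor because one end of it rests on a limit: the limit of > 50000 nM in this assay, at which 2 of the 4 values shown sit.

The compounds shown do not separate the added methyl from the changed place of the chlorine, as none carries a phenyl with only the methyl or with the chlorine alone at that place. Also open, from the compounds shown here alone, is how this core responds to an amine or a carboxylic acid on the same phenyl ring.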